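Swapping an Amino for a Carbamoyl on the Pyridine

The source may hold more compounds than are shown below. What is called first, only, known or untested is meant among the compounds shown, and "the series" means these compounds.

Going by the values given here, compound 2, with the structure `CCc1ccc2c(c1)c(=O)c(C(=O)Nc1ccc(Oc3ccnc(N)c3Cl)c(F)c1)c(C)n2C`, is the only compound here with a real number in an assay on isolated protein for inhibition of tyrosine-protein kinase receptor UFO (Homo sapiens), read by FRET and Z'-LYTE, with a stated time of 1.5 h; a lower number here means a stronger inhibitor, a higher number a weaker inhibitor: compound 2 gives 72 nM. Compound 1, with the structure `CCc1ccc2c(c1)c(=O)c(C(=O)Nc1ccc(Oc3ccnc(Cl)c3)c(F)c1)c(C)n2C`, reaches only a limit of the assay, giving > 10000 nM in this assay. Among the compounds with values here, the one measured step, an at least 130-fold lower number from compound 1 to compound 2 (2.14 log units; beyond the scatter), shows that the group on the pyridine ring controls inhibition strongly, though part of that reading rests on (the limit of > 10000 nM in this assay, at which 1 of the 2 values shown sits).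

Compound 3, with the structure `CCc1ccc2c(c1)c(=O)c(C(=O)Nc1ccc(Oc3ccnc(C(N)=O)c3Cl)c(F)c1)c(C)n2C`, keeps everything in compound 2 except one change: carbamoyl in place of amino on an aromatic carbon. The carbamoyl, like the amino it replaces, carries a hydrogen-bond donor and acceptor, so the large step already seen does not point clearly in either direction here; it only shows this position is sensitive. A modest weakening is expected, so the step of a 1.7-fold higher number from compound 2 to compound 3 (0.22 log units; within the scatter) is estimated to stay near the scatter. Compound 3 is therefore expected to give about 120 nM in this assay, within a range from 30 nM to 500 nM.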

Compound 3, half-maximal inhibitory concentration: > 10000 nM
Compound 3: only a limit was reported (the forecaster's own chance of this, stated with the estimate: 5%); middle value at least 83-fold (1.92 log units) from the limit.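

The change from amino to carbamoyl gives an at least 130-fold higher number from compound 2 to compound 3 (2.14 log units; beyond the scatter) in this assay, so this position tolerates far less than the earlier step could show. Compound 3 keeps the chloro group and the rest of compound 2, which means the chloro group alone does not preserve the inhibition, and the amino group matters here in a way compound 1 could not separate out. Amino and carbamoyl also have the same counts of hydrogen-bond donors and acceptors, so in this pair those counts do not decide the outcome.

Going by these compounds, the step between compound 1 and compound 3 cannot be read, and the true size of the loss in compound 3 also stays unknown, since its value is only a limit of the assay: the limit of > 10000 nM in this assay, at which 2 of the 3 values shown sit. It remains open whether a methylamino group, a hydroxyl group or a methyl group at this place would keep the inhibition of compound 2 or lose it as the carbamoyl does.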